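Naphthyl replaces chlorophenyl on the thioether arm

A few compounds are considered here, and "the series" means these few. Any claim that something is new, unique, unknown or untested is made for them only; others in the source may bear on it.

Measured so far:
compound 1, `Cc1cc(S(=O)(=O)/N=C(\N)N/N=C/C#Cc2ccccc2)c(SCc2ccc(C(F)(F)F)cc2)cc1Cl`: 93000 nM
compound 2, `Cc1cc(S(=O)(=O)/N=C(\N)N/N=C/C#Cc2ccccc2)c(SCc2ccccc2Cl)cc1Cl`: 14000 nM

Both compounds share a core and differ only in the aryl group on a saturated chain carbon bound to a sulfur. In a functional assay on HeLa cells (Homo sapiens) for antiproliferative activity, read by MTT assay, with a stated time of 72 h (on this read-out higher numbers stand for weaker inhibition and lower numbers for stronger inhibition), compound 2 stands at the lowest of the two numbers; its nearest neighbour is compound 1, and the step of a 6.6-fold lower number from compound 1 to compound 2 (0.82 log units; beyond the scatter) lies beyond the scatter.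

Compound 3, `Cc1cc(S(=O)(=O)/N=C(\N)N/N=C/C#Cc2ccccc2)c(SCc2cccc3ccccc23)cc1Cl`, is not yet measured. It differs from compound 2 in one place: naphthalen-1-yl in place of 2-chlorophenyl on a saturated chain carbon bound to a sulfur. Going by the values given here, the only measured step that bears on this change is a 6.6-fold lower number from compound 1 to compound 2 (0.82 log units; beyond the scatter), which swapped one aryl group for another at the same carbon and gave a modest lowering. Among the compounds with values here, no measured pair shows what a second fused ring does here, so the direction is uncertain. The size of the step from compound 2 to compound 3 in this assay is expected to stay within the scatter or be modest, a 1.4-fold higher number from compound 2 to compound 3 (0.15 log units; within the scatter). Compound 3 is estimated at 20000 nM, with a range from 5000 nM to 80000 nM.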

Compound 3, half-maximal inhibitory concentration: 8000 nM
Estimate against measurement, compound 3: 2.5-fold (0.40 log units) above; low and high end bracket the measured number.
By their numbers in this assay, from the lowest: compounds 3 and 2 (each within the scatter of the next); then compound 1.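

In this assay, naphthalen-1-yl in place of 2-chlorophenyl gives a 1.8-fold lower number from compound 2 to compound 3 (0.24 log units; within the scatter), so this swap of 7 heavy atoms with one aromatic ring for 10 heavy atoms with 2 aromatic rings leaves the reading unresolved from that of the chlorinated parent. The wider comparison, a 12-fold lower number from compound 1 to compound 3 (1.07 log units; beyond the scatter), is large, and with the earlier step it sets 4-(trifluoromethyl)phenyl apart as the one of the three aryl groups on this saturated chain carbon bound to a sulfur that reads clearly higher, while 2-chlorophenyl and naphthalen-1-yl cannot be separated from each other. No measurement on hand accounts for this difference between the aryl groups.

The compounds shown leave open whether the higher number belongs to the trifluoromethyl group itself or to any group at that place on the ring, a question that a plain phenyl or a 4-chlorophenyl at this carbon would address. They also leave open how far this carbon accepts a non-aromatic group such as cyclohexyl, or a longer chain between the sulfur and the ring.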